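The source may report more compounds than this note shows. Statements on the series, on what has been measured and on what is new or still open speak of the compounds shown alone.

The measured compounds:
Compound 1, `C/C=C/C(=O)N(Cc1ccc(OC)c([N+](=O)[O-])c1)c1cc(OC)c(OC)c(OC)c1`: 590 nM
Compound 2, `COc1ccc(CNc2cc(OC)c(OC)c(OC)c2)cc1[N+](=O)[O-]`: 19400 nM
Compound 3, `CCCCC(=O)N(Cc1ccc(OC)c(O)c1)c1cc(OC)c(OC)c(OC)c1`: 66 nM

In a functional assay on MGC-803 cells (Homo sapiens) for inhibition, read by MTT assay, with a stated time of 48 h (a lower number here means a stronger inhibitor, a higher number a weaker inhibitor), compound 2 gives the highest number of the three measured compounds, so it is the weakest inhibitor shown here. Its nearest neighbour is compound 1, reached by the step of a 33-fold higher number from compound 1 to compound 2 (1.52 log units; beyond the scatter), which lies beyond the scatter. Compound 3 stands further away still, with the lowest number of the three.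

Compound 4, `COc1ccc(CNc2cc(OC)c(OC)c(OC)c2)cc1`, differs from compound 2 in one place:

hydrogen in place of nitro on an aromatic carbon

For the measured compounds named here, no measured pair differs in just this way. Going by the values given here, the only recorded step concerns a change on a nitrogen, not on the aromatic ring, and compound 3 differs from compound 2 in more than one place, so nothing here bears directly on removing the nitro group. With no guide, the step in this assay is expected to be small, a 1.0-fold higher number from compound 2 to compound 4 (0.01 log units; within the scatter), in no particular direction. Compound 4 is therefore estimated at 20000 nM, with a range from 6000 nM to 60000 nM.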

Compound 4, half-maximal inhibitory concentration: 11400 nM
The estimate for compound 4 lay 1.8-fold (0.24 log units) above the measured number; the measured number falls inside the stated range.
By their numbers in this assay, from the lowest: compound 3; then compound 1; then compounds 4 and 2 (each within the scatter of the next).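

Swapping the nitro group for hydrogen, on the aromatic carbon ortho to a methoxy group, gives a 1.7-fold lower number from compound 2 to compound 4 (0.23 log units; within the scatter) in this assay. For the compounds shown here, this is the first look at a change on the aromatic ring rather than on the nitrogen, and it shows that, with the nitrogen carrying a hydrogen, losing the nitro group makes no change that can be told from the scatter, unlike the large step of a 33-fold higher number from compound 1 to compound 2 (1.52 log units; beyond the scatter) on the nitrogen. No measurement shown gives a reason for this result.

On these data alone, whether the nitro group matters any more when the nitrogen carries an acyl group, as in compound 1, stays open. So does the effect of other groups at this carbon, such as an amine or a chlorine atom.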